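A few compounds are considered here, and "the series" means these few. Any claim that something is new, unique, unknown or untested is made for them only; others in the source may bear on it.

Working notes on the series. In a functional assay for antagonist activity at transient receptor potential cation channel subfamily V member 1 (Homo sapiens), read by FLIPR and calcium flux (a higher number here means a weaker inhibitor, a lower number a stronger inhibitor), compound 1 `O=C1COc2ccc(NC(=O)C3CCN(c4ccccc4Br)CC3)cc2N1` gives 160 nM and compound 2 `O=C1COc2ccc(NC(=O)C3CCN(c4cccc(Br)c4)CC3)cc2N1` gives 330 nM; the step of a 2.1-fold higher number from compound 1 to compound 2 (0.31 log units; beyond the scatter) is modest. Compound 3 `Cc1ccccc1N1CCC(C(=O)Nc2ccc3c(c2)NC(=O)CO3)CC1` gives 150 nM in this assay, which is the lowest of the three numbers shown, though its gap to compound 1 is within the scatter and only the step of a 2.2-fold lower number from compound 2 to compound 3 (0.34 log units; beyond the scatter) lies beyond it. Compound 4 `CC(C)c1ccccc1N1CCC(C(=O)Nc2ccc3c(c2)NC(=O)CO3)CC1` is not yet measured. It differs from compound 3 in one place: isopropyl in place of methyl on an aromatic carbon. Among the measured compounds shown here, no measured step here enlarges a group on that ring; the nearest case is a 1.1-fold lower number from compound 1 to compound 3 (0.03 log units; within the scatter), in which the group on the same aromatic carbon was swapped without a shift beyond the scatter. On that basis a small step is expected from compound 3 to compound 4 in this assay, a 1.1-fold higher number from compound 3 to compound 4 (0.05 log units; within the scatter), with no clear direction. The estimate for compound 4 in this assay is 170 nM, within a range of 60 nM to 500 nM.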

Compound 4, half-maximal inhibitory concentration: 180 nM
Compound 4: middle estimate off by 1.1-fold (0.02 log units), on the low side; measured number inside the range.
By their numbers in this assay, from the lowest: compounds 3, 1, 4 and 2 (each within the scatter of the next, the first and the last beyond it).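

In this assay, going from methyl to isopropyl on this aromatic carbon, ortho to a large group, moves the number by no more than the scatter (a 1.2-fold higher number from compound 3 to compound 4 (0.08 log units; within the scatter)), and the same holds for isopropyl in place of bromo (a 1.1-fold higher number from compound 1 to compound 4 (0.05 log units; within the scatter)), so bromo, methyl and isopropyl cannot be told apart at this place. The step from 3-bromophenyl to 2-isopropylphenyl (a 1.8-fold lower number from compound 2 to compound 4 (0.26 log units; within the scatter)) also stays within the scatter, unlike the steps from compound 2 to compound 1 and compound 3, which are printed as beyond it or reversed from it, so compound 2 no longer stands clearly apart from the other compounds. Nothing in hand accounts for this flat response.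

Open, from the compounds shown here alone, is whether the flat response holds for a larger group such as tert-butyl or phenyl on this carbon. An amine, a carboxylic acid or a methoxy group at the same place also remains untested among the compounds shown, as does the phenyl ring with no group there.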